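A few compounds are considered here, and "the series" means these few. Any claim that something is new, unique, unknown or untested is made for them only; others in the source may bear on it.

Three compounds have so far been measured in a functional assay for inhibition, tested at 100 uM; on this read-out lower numbers stand for less inhibition and higher numbers for more inhibition at the one concentration tested (going by the name of the read-out):

Compound 1 `Cc1ccc(S(=O)(=O)/C=C/S(=O)(=O)CC2=NCCO2)cc1`: 74.2%
Compound 2 `Cc1ccc(S(=O)(=O)c2c[nH]cc2S(=O)(=O)CC2=NCCO2)cc1`: 78.5%
Compound 3 `O=S(=O)(CC1=NCCO1)c1c[nH]cc1S(=O)(=O)c1ccccc1`: 87.7%

Compound 2 holds the second highest of the three numbers. Its nearest neighbour is compound 1, whose number lies a little lower, and the two values fall within the scatter of each other. For the measured compounds named here, the only single-point step among the measured compounds is a number 9.2 percentage points higher from compound 2 to compound 3 (within the scatter), a change of hydrogen in place of methyl on an aromatic carbon, and it too stays within the scatter. All three compounds thus sit within the scatter of one another on this read-out.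

Compound 4 `Cc1ccc(S(=O)(=O)c2c[nH]cc2S(=O)(=O)CC2=NCCS2)cc1` is the next compound to be measured. It differs from compound 2 by a group of 5 heavy atoms (3 carbon, 1 nitrogen, 1 sulfur; one five-membered non-aromatic ring with 2 hetero atoms) in place of a group of 5 heavy atoms (3 carbon, 1 nitrogen, 1 oxygen; one five-membered non-aromatic ring with 2 hetero atoms), on a saturated chain carbon bound to a sulfonyl sulfur. Going by the values given here, no measured step touches this part of the molecule: the one step recorded, from compound 2 to compound 3, concerns the aromatic methyl and not the group on the saturated chain carbon bound to the sulfonyl sulfur. There is therefore no basis for expecting a step beyond the scatter in either direction, and the expected step of a number 0.5 percentage points lower from compound 2 to compound 4 (within the scatter) is taken as no change beyond the scatter. Compound 4 is accordingly estimated to give 78%, with a range from 62% to 92%.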

Compound 4, a percentage reported as inhibition, at one concentration (the size of the read-out at that concentration, not a potency): 23.7%
Compound 4: the middle estimate sits 54.3 percentage points above what was measured, outside the stated range (below it).
By their numbers in this assay, from the lowest: compound 4; then compounds 1, 2 and 3 (each within the scatter of the next, the first and the last beyond it).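

In this assay, for the compounds shown here, the group on the saturated chain carbon bound to a sulfonyl sulfur proves decisive: putting sulfur in place of oxygen in the five-membered non-aromatic ring gives a number 54.8 percentage points lower from compound 2 to compound 4 (beyond the scatter), whereas the only earlier step, at the aromatic carbon, was a number 9.2 percentage points higher from compound 2 to compound 3 (within the scatter). The two groups match in heavy-atom count, ring type, double bonds outside aromatic rings, hydrogen-bond donors and acceptors, and net charge, so these counts do not separate them, and the exchange of this one ring atom is enough to produce a large step at this position. Nothing available here accounts for the size of this step.

Going by these compounds, it remains open whether an open-chain amine, a carboxylic acid or a six-membered ring holding nitrogen and oxygen on this same carbon would keep the number of compound 2 at 78.5% or lose it as the sulfur ring does. Also open, on these data alone, is whether the same exchange of oxygen for sulfur would give a step of similar size on the core of compound 3, which carries hydrogen in place of the aromatic methyl.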